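A few compounds are considered here, and "the series" means these few. Any claim that something is new, unique, unknown or untested is made for them only; others in the source may bear on it.

In a functional assay on SGC-7901 cells (Homo sapiens) for antiproliferative activity, read by MTT assay, with a stated time of 72 h (on this read-out higher numbers stand for weaker inhibition and lower numbers for stronger inhibition), compound 2 `COc1ccc(-c2sccc2-c2cc(OC)c(OC)c(OC)c2)cc1` gives 5470 nM and compound 3 `COc1ccc(-c2sccc2-c2cc(OC)c(OC)c(OC)c2)cc1[N+](=O)[O-]` gives 3310 nM, two values within the scatter of each other. Putting the nitro in place of hydrogen gave a 1.7-fold lower number from compound 2 to compound 3 (0.22 log units; within the scatter). For compound 1 `CCOC(=O)c1cc(-c2cc(OC)c(OC)c(OC)c2)c(-c2ccc(OC)c(OCc3ccccc3)c2)s1`, the result is a limit and not a number: > 100000 nM. Compound 4 `COc1ccc(-c2sccc2-c2cc(OC)c(OC)c(OC)c2)cc1OCc1ccccc1` has benzyloxy in place of nitro on an aromatic carbon. For the measured compounds named here, the one measured step involving the nitro is small, but the incoming benzyloxy is a much larger group, so that step is only a weak guide. Compound 1 also carries benzyloxy, though it differs elsewhere too, and its limit of > 100000 nM points towards weaker inhibition. The expected change is a 3.6-fold higher number from compound 3 to compound 4 (0.56 log units; beyond the scatter). For compound 4, the estimated value is 12000 nM, with an expected range from 3000 nM to 60000 nM.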

Compound 4, half-maximal inhibitory concentration: > 100000 nM
Compound 4 was reported as a limit; the forecaster's own chance of this, stated with the estimate: 15%; middle value at least 8.3-fold (0.92 log units) away from the limit.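

In this assay, hydrogen and nitro at this position, ortho to a methoxy group, gave values within the scatter of each other, but benzyloxy gives an at least 30-fold higher number from compound 3 to compound 4 (1.48 log units; beyond the scatter) and an at least 18-fold higher number from compound 2 to compound 4 (1.26 log units; beyond the scatter). So this position does not accept every group, and inhibition is largely lost with benzyloxy, which brings a six-membered aromatic ring. The step between compound 1 and compound 4 cannot be read, since both values are limits and not numbers: the limit of > 100000 nM in this assay, at which 2 of the 4 values shown sit.

From the compounds shown here alone, whether the loss follows from the ring or from the oxygen joining it stays open. A hydroxyl, an amine or a longer chain without a ring at this position could separate the two.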